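The compounds below may be only part of what the source reports. "The series", "measured", "known", "first", "only" and "open" are said of these compounds alone.

In a functional assay on BXPC-3 cells (Homo sapiens) for antiproliferative activity, read by MTT assay, with a stated time of 24 h (on this read-out higher numbers stand for weaker inhibition and lower numbers for stronger inhibition), three compounds built on one shared core have been read. Compound 1 `CCn1c(C(=O)NC(C)(C)CO)ccc1C(CC)(CC)c1ccc(OCS(=O)(=O)c2ccccc2)c(C)c1` gives 18300 nM, and compound 2 `CCn1c(C(=O)N[C@H](CO)C(C)C)ccc1C(CC)(CC)c1ccc(OCS(=O)(=O)c2ccccc2)c(C)c1` gives 7720 nM. Compound 3 `CCn1c(C(=O)N[C@H](CO)CCCO)ccc1C(CC)(CC)c1ccc(OCS(=O)(=O)c2ccccc2)c(C)c1` is reported only as a limit, > 50000 nM. It therefore stands at the weak end of the three, with measured steps of an at least 2.7-fold higher number from compound 1 to compound 3 (0.43 log units; beyond the scatter) and an at least 6.4-fold higher number from compound 2 to compound 3 (0.81 log units; beyond the scatter).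

Compound 4 `CCn1c(C(=O)N[C@@H](C)C(=O)O)ccc1C(CC)(CC)c1ccc(OCS(=O)(=O)c2ccccc2)c(C)c1` has not yet been measured. It carries 1-carboxyethyl on the amide-type nitrogen in place of the side group of compound 3: a group of 5 heavy atoms (3 carbon, 2 oxygen; no ring) in place of a group of 7 heavy atoms (5 carbon, 2 oxygen; no ring), on an amide-type nitrogen.

Going by the values given here, all the measured steps changed this same group. Besides the two steps into compound 3, there is a 2.4-fold lower number from compound 1 to compound 2 (0.37 log units; beyond the scatter). Among the compounds with values here, none of the measured compounds carries 1-carboxyethyl, and the steps into compound 3 give only bounds, so the size of the new step is poorly fixed. The group in compound 4 keeps the 2 oxygen atoms counted for the group in compound 3, and that group went with an at least 2.7-fold higher number from compound 1 to compound 3 (0.43 log units; beyond the scatter). Compound 4 is therefore expected to remain weak, near the limit of this assay, with no firm direction relative to compound 3. The expected step is an at least 1.4-fold lower number from compound 3 to compound 4 (0.15 log units; that floor lies within the scatter). Compound 4 is estimated at 35000 nM, within an expected range of 12000 nM to 100000 nM.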

Compound 4, half-maximal inhibitory concentration: 20800 nM
Beside the measured number, compound 4's estimate is 1.7-fold (0.23 log units) above it; the range from low to high includes it.
By their numbers in this assay, from the lowest: compound 2; then compounds 1 and 4 (each within the scatter of the next). At a limit, above all of these: compound 3.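

In this assay, 1-carboxyethyl on the amide-type nitrogen gives a read value, and it sits level with the side group of compound 1 (a 1.1-fold higher number from compound 1 to compound 4 (0.06 log units; within the scatter)) but does not match compound 2 (a 2.7-fold higher number from compound 2 to compound 4 (0.43 log units; beyond the scatter)). The two oxygen atoms counted in this group are also counted in the group of compound 3, yet the change gives an at least 2.4-fold lower number from compound 3 to compound 4 (0.38 log units; beyond the scatter), so among these compounds that oxygen count alone does not place a compound at the weak end. Compound 3 is held only at a limit, so this last step is a bound and its full size stays unknown: the limit of > 50000 nM in this assay, at which 1 of the 4 values shown sits.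

The compounds shown leave open whether the carboxylic acid or the shorter chain accounts for the difference from compound 2, since the side groups differ in more than one feature. As far as these compounds go, a 1-(hydroxymethyl)ethyl group, a methyl ester or a primary amide at this place on the amide-type nitrogen would separate those features, and the effect of the opposite stereocentre in 1-carboxyethyl also remains unknown.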